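Adding a Nitro Group to the Furan of Compound 2

A few compounds are considered here, and "the series" means these few. Any claim that something is new, unique, unknown or untested is made for them only; others in the source may bear on it.

Of the compounds shown here, two have so far been tested in a functional assay on the whole organism (strain Wistar Albino) for inhibition, with Rattus norvegicus as the target, read by paw edema, with a stated time of 1 h, at a dose of 20 mg/kg; on this read-out lower numbers stand for less inhibition and higher numbers for more inhibition at the one dose given (going by the name of the read-out). Compound 1 `Cc1occc1-c1nnc2sc(-c3ccnc4ccccc34)nn12` gives 12.5% in this assay. Compound 2 `COc1ccc(Cl)c(-c2nnc3n2NC(c2ccco2)S3)c1` gives 13.9% in this assay; the two numbers lie within the usual scatter of each other, so neither compound can be set above the other on these data. Compound 3 `COc1ccc(Cl)c(-c2nnc3n2NC(c2ccc([N+](=O)[O-])o2)S3)c1` has not been measured yet. It differs from compound 2 in one place: nitro in place of hydrogen on an aromatic carbon. Within the data shown here, no step between measured compounds is available, so nothing among the measured pairs shows what such a swap does to paw edema inhibition. The change from furan-2-yl to 5-nitrofuran-2-yl is expected to shift the read-out by a number 3.1 percentage points higher from compound 2 to compound 3 (within the scatter), a step of modest size, upward if anything, that may well stay within the scatter. Compound 3 is therefore estimated to give 17% in this assay, with a likely range from 8% to 30%.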

Compound 3, a percentage reported as inhibition, in the whole organism at one dose (the size of the read-out at that dose, not a potency): 15.6%
Compound 3: middle estimate off by 1.4 percentage points, on the high side; low and high end bracket the measured number.
By their numbers in this assay, from the lowest: compounds 1, 2 and 3 (each within the scatter of the next).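

Putting nitro in place of hydrogen on the furan carbon next to the ring oxygen gives a number 1.7 percentage points higher from compound 2 to compound 3 (within the scatter) in this assay. Among these compounds, this is the first step measured at this position, and it shows that the swap from furan-2-yl to 5-nitrofuran-2-yl adds three heavy atoms there without a change that can be told apart from the scatter. Nothing measured on these compounds speaks to why the step has this size.

As far as these compounds go, a single swap says little about the position as a whole, so it remains open whether an amine or a carboxylic acid on the same carbon would move the read-out beyond the scatter. From the compounds shown here alone, it also remains open whether nitro and hydrogen at this position would still lie this close at another dose or another time point.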